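Methylsulfanyl purine in a cyclopropylidene nucleoside-like series

The compounds below may be only part of what the source reports. "The series", "measured", "known", "first", "only" and "open" are said of these compounds alone.

Measured compounds
- compound 1 `CC(C)CSc1nc(N)nc2c1ncn2/C=C1/CC1(CO)CO`: "not determined" (no result reported)
- compound 2 `Nc1nc(NC2CC2)c2ncn(/C=C3/CC3(CO)CO)c2n1`: > 20000 nM

In an ADME assay on MOLT-3 cells (Homo sapiens) for cytotoxicity, with a stated time of 7 days (on this read-out higher numbers stand for lower toxicity in this test and lower numbers for higher toxicity in this test), compound 1 stands with no number of its own; its entry is "not determined" (no result reported). Compound 2 returns a limit of the test rather than a number in this assay, namely > 20000 nM. Going by the values given here, the only evidence on this read-out is therefore (the limit of > 20000 nM in this assay, at which 1 of the 2 values shown sits), which places one of the two recorded entries at the top end of what the test reports; nothing here fixes where the shared core sits below that edge.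

Compound 3 `CSc1nc(N)nc2c1ncn2/C=C1/CC1(CO)CO` is the untested partner of compound 1. The change between them is hydrogen in place of isopropyl on a saturated chain carbon bound to a sulfur. With compound 1 carrying no number in this assay, no measured step can be set against this change, and no shift beyond the scatter in either direction is expected on the single limit shown for compound 2.

For compound 3 in this assay the half-maximal cytotoxic concentration is estimated at 20000 nM, with a range from 5000 nM to 60000 nM, most plausibly returned again as a limit rather than a number.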

Compound 3, half-maximal cytotoxic concentration: > 20000 nM
Compound 3 ended at the assay's limit; the forecaster's own chance of this, stated with the estimate: 70%; the middle value sits exactly at the limit.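

No step can be read among compound 1, compound 2 and compound 3 in this assay, since the entries for compound 2 and compound 3 are both limits of the test. Still open is where the half-maximal cytotoxic concentrations of these compounds actually lie, and whether methylsulfanyl and cyclopropylamino differ there at all: the limit of > 20000 nM in this assay, at which 2 of the 3 values shown sit.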